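The compounds below may be only part of what the source reports. "The series", "measured", "known", "first", "only" and "open" are said of these compounds alone.

For the measured compounds named here, compound 3 `Nc1scc(CN2CCN(c3ccccc3Cl)CC2)c1C(=O)c1ccc(Cl)cc1` gives -18% in a functional assay on CHO cells with adenosine receptor A1 (Homo sapiens) as the target, read by cAMP accumulation and immunoassay, with a stated time of 6 min, tested at 10 uM (a lower number here means a stronger effect, a higher number a weaker effect of the compound at the concentration tested), the highest of the three numbers measured so far. Compound 2 `Nc1scc(CN2CCN(c3cccnc3)CC2)c1C(=O)c1ccc(Cl)cc1` gives -23% in this assay, and a number 5 percentage points higher from compound 2 to compound 3 (within the scatter). Compound 1 `Nc1scc(CN2CCN(c3ccc(Cl)cc3Cl)CC2)c1C(=O)c1ccc(Cl)cc1` gives -74% in this assay, and a number 56 percentage points higher from compound 1 to compound 3 (beyond the scatter). Compound 4 `Nc1scc(CN2CCN(c3ccc(Cl)c(Cl)c3)CC2)c1C(=O)c1ccc(Cl)cc1` differs from compound 3 by 3,4-dichlorophenyl in place of 2-chlorophenyl on an amine nitrogen in a ring. Going by the values given here, two measured steps bear on this change, a number 56 percentage points higher from compound 1 to compound 3 (beyond the scatter) and a number 51 percentage points higher from compound 1 to compound 2 (beyond the scatter), both large and both moving away from the 2,4-dichlorophenyl of compound 1. Compound 4 carries a 3,4-dichlorophenyl again, so a large step downward, beyond the scatter, is expected, roughly a number 42 percentage points lower from compound 3 to compound 4 (beyond the scatter). Compound 4 is therefore estimated at -60% in this assay, with a range from -85% to -25%.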

Compound 4, a percentage reported as activity, at one concentration (the size of the read-out at that concentration, not a potency): -62%
Estimate against measurement, compound 4: 2 percentage points above; the measured number falls inside the stated range.
By their numbers in this assay, from the lowest: compound 1; then compound 4; then compounds 2 and 3 (each within the scatter of the next).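

In this assay the 3,4-dichlorophenyl group on the ring nitrogen gives a number 44 percentage points lower from compound 3 to compound 4 (beyond the scatter) and a number 39 percentage points lower from compound 2 to compound 4 (beyond the scatter). Two chlorines on this phenyl ring thus go with a stronger effect in both arrangements shown, not only in the 2,4-dichlorophenyl of compound 1, yet the arrangement still counts, with a number 12 percentage points higher from compound 1 to compound 4 (beyond the scatter). No measured evidence explains these differences. Still open is whether the chlorines themselves are needed: the compounds shown do not tell how methoxy or trifluoromethyl groups on this phenyl ring would compare.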